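A few compounds are considered here, and "the series" means these few. Any claim that something is new, unique, unknown or untested is made for them only; others in the source may bear on it.

Measured compounds:
- compound 1 `COc1cc(Cl)cc(-c2nn(-c3cccc(NC(=O)c4ccc(Cl)c(Cl)c4)c3)cc2-c2ccncc2)c1` gives 71.6% in a functional assay on IGROV-1 cells (Homo sapiens) for inhibition, read by sulforhodamine B assay, with a stated time of 48 h, tested at 10 uM; on this read-out higher numbers stand for a weaker effect at the one concentration tested and lower numbers for a stronger effect
- compound 2 `O=C(Nc1cccc(-n2cc(-c3ccncc3)c(-c3cc(O)cc(Cl)c3)n2)c1)Nc1ccc(Cl)c(C(F)(F)F)c1` gives 30.6% in this assay
- compound 3 `O=C(Nc1cccc(-n2cc(-c3ccncc3)c(-c3cc(O)cc(Cl)c3)n2)c1)Nc1ccc(Cl)c(Cl)c1` gives 26% in this assay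

Compound 2 stands second highest of the three numbers. Its nearest neighbour is compound 3, and the step of a number 4.6 percentage points lower from compound 2 to compound 3 (within the scatter) lies within the scatter, so the two are not separated. Compound 1 lies furthest from compound 2, a gap beyond the scatter, but compound 1 differs from compound 2 in more than one place, so that gap cannot be assigned to a single change.

The unmeasured compound 4 `COc1cc(Cl)cc(-c2nn(-c3cccc(NC(=O)Nc4ccc(Cl)c(C(F)(F)F)c4)c3)cc2-c2ccncc2)c1` is reached from compound 2 by methyl in place of hydrogen on an oxygen on an aromatic ring. For the measured compounds named here, no measured step covers this change: the only step in hand, from compound 2 to compound 3, concerns a different position. Compound 1 carries the methoxy group, but paired with an amide rather than a urea, so its number is not a guide on its own. Going by the values given here, with no direct precedent, the expectation for compound 4 is a step of a number 9.4 percentage points higher from compound 2 to compound 4 (within the scatter) that need not exceed the scatter, with a wide range. Compound 4 is estimated at 40%, between 22% and 65%.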

Compound 4, a percentage reported as activity, at one concentration (the size of the read-out at that concentration, not a potency): 30.2%
Estimate against measurement, compound 4: 9.8 percentage points above; measured number inside the range.
By their numbers in this assay, from the lowest: compounds 3, 4 and 2 (each within the scatter of the next); then compound 1.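

Notes on the series: in this assay, hydroxy to methoxy on the 3-chloro-5-hydroxyphenyl group gives a number 0.4 percentage points lower from compound 2 to compound 4 (within the scatter), so with the urea held fixed, methyl on this oxygen leaves the read-out unseparated from that of the hydroxy compound. The large effect belongs to a different change, with methoxy held fixed: a number 41.4 percentage points lower from compound 1 to compound 4 (beyond the scatter), where (4-chloro-3-(trifluoromethyl)phenyl)amino replaces 3,4-dichlorophenyl on a carbonyl carbon, a single replacement that brings in both the urea nitrogen and the trifluoromethyl group. No measurement is available that would explain either step.

On these data alone, whether ethoxy or an amine in place of hydroxy would behave like methoxy remains open. Also open, as far as these compounds go, is how the large step divides between the urea nitrogen and trifluoromethyl in place of chloro.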